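This account rests on a few compounds, and the source may have more. Where it says the series, first, only, none or still open, it means among the compounds named here.

Of the compounds shown here, three sharing one core have been tested in a functional assay on MKN-45 cells (Homo sapiens) for cytotoxicity, read by MTT assay, with a stated time of 72 h; on this read-out lower numbers stand for stronger inhibition and higher numbers for weaker inhibition. Compound 1 `CN(C)CCn1cnnc1-c1cc(Oc2ccc(NC(=O)N/N=C/c3ccc(O)c(F)c3)cc2F)ccn1` gives 1970 nM. Among the three numbers known, compound 1 stands second highest. Its nearest neighbour is compound 2 `COc1ccc(/C=N/NC(=O)Nc2ccc(Oc3ccnc(-c4nncn4CCN(C)C)c3)c(F)c2)c(OC)c1OC`, which gives 2020 nM, so that the change a 1.0-fold higher number from compound 1 to compound 2 (0.01 log units; within the scatter) is one the measurement cannot tell apart from repetition. Its furthest neighbour is compound 3 `CN(C)CCn1cnnc1-c1cc(Oc2ccc(NC(=O)N/N=C/c3c(Cl)cccc3Cl)cc2F)ccn1`, which gives 160 nM, the step being a 12-fold lower number from compound 1 to compound 3 (1.09 log units; beyond the scatter); from compound 2 the corresponding step is a 13-fold lower number from compound 2 to compound 3 (1.10 log units; beyond the scatter).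

Compound 4 `COc1cc(/C=N/NC(=O)Nc2ccc(Oc3ccnc(-c4nncn4CCN(C)C)c3)c(F)c2)cc(OC)c1OC` is now to be measured in this assay. It differs from compound 1 in one place: 3,4,5-trimethoxyphenyl in place of 3-fluoro-4-hydroxyphenyl on a carbon with a double bond to nitrogen. Going by the values given here, the step that bears on this is the one from compound 1 to compound 2, where 2,3,4-trimethoxyphenyl replaced the same 3-fluoro-4-hydroxyphenyl on a carbon with a double bond to nitrogen and gave a 1.0-fold higher number from compound 1 to compound 2 (0.01 log units; within the scatter). Compound 3 shows that a change at this carbon can move the number far, but its 2,6-dichlorophenyl is not a trimethoxyphenyl. For compound 4 the expected step is therefore a 1.0-fold higher number from compound 1 to compound 4 (0.01 log units; within the scatter), nothing beyond the scatter. Compound 4 is estimated to give 2000 nM, within 900 nM to 4500 nM.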

Compound 4, half-maximal inhibitory concentration: 2900 nM
Compound 4: the middle estimate sits 1.5-fold (0.16 log units) below what was measured; low and high end bracket the measured number.
By their numbers in this assay, from the lowest: compound 3; then compounds 1, 2 and 4 (each within the scatter of the next).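

In this assay, 3,4,5-trimethoxyphenyl at this carbon cannot be told apart from 3-fluoro-4-hydroxyphenyl (a 1.5-fold higher number from compound 1 to compound 4 (0.17 log units; within the scatter)) or from 2,3,4-trimethoxyphenyl (a 1.4-fold higher number from compound 2 to compound 4 (0.16 log units; within the scatter)), so moving the methoxy groups around the ring shows no measurable effect in this pair. The contrast with 2,6-dichlorophenyl is large (an 18-fold higher number from compound 3 to compound 4 (1.26 log units; beyond the scatter)), which leaves compound 3 as the only one of the four set apart from the others. No measurement is available to explain this difference.

What the compounds leave open is whether the chlorine atoms themselves matter, or how many of them are needed. A plain phenyl, a phenyl carrying a single chlorine, or one carrying bromine or an amine could help settle how far this position tolerates change.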